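Methoxy for amino at the chain end

A few compounds are considered here, and "the series" means these few. Any claim that something is new, unique, unknown or untested is made for them only; others in the source may bear on it.

- Compound 1 `CN(C)Cc1cc(F)ccc1-c1nc(-c2ccc3[nH]c(=O)oc3c2)cs1` in a functional assay on TOV21G cells (Homo sapiens) for antiproliferative activity, read by sulforhodamine B assay, with a stated time of 3 days (a higher number here means a weaker inhibitor of growth, a lower number a stronger inhibitor of growth), gives > 50000 nM (a limit, not a number)
- Compound 2 `NCCOCc1cc(F)ccc1-c1nc(-c2ccc3[nH]c(=O)oc3c2)cs1` in this assay gives > 50000 nM (a limit, not a number)

Compound 2 has no exact value on the numbers shown, since its result of > 50000 nM is a limit of the assay. Among the compounds with values here, the picture across the series so far is brief: the limit of > 50000 nM in this assay, at which 2 of the 2 values shown sit. Compound 3 `COCCOCc1cc(F)ccc1-c1nc(-c2ccc3[nH]c(=O)oc3c2)cs1` keeps the shared core and alters only the end of the chain: methoxy in place of amino on a saturated chain carbon, two bonds along the chain from an oxygen on a saturated carbon. In words, this puts methoxy in place of amino on a saturated chain carbon, two bonds along the chain from an oxygen on a saturated carbon.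

Within the data shown here, only one measured step bears on this change, and it offers no size to carry over: a step that the two limits leave unreadable from compound 1 to compound 2. With no readable step to draw on, the expectation rests on compound 2 and its limit of > 50000 nM. The expected result is a number no higher from compound 2 to compound 3 (the limit leaves the size open), so no step beyond the usual scatter is expected in this assay. Compound 3 is estimated at 50000 nM, with an expected range from 25000 nM to 100000 nM.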

Compound 3, concentration for 50% growth inhibition: > 50000 nM
Compound 3 ended at the assay's limit; the forecaster's own chance of this, stated with the estimate: 80%; the middle value sits exactly at the limit.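

In this assay compound 3 gives > 50000 nM, which is a limit of the assay and not a number. Within the data shown here, no step between compound 1, compound 2 and compound 3 can be read. The compounds shown leave open how these chain ends compare in strength of growth inhibition, as the results share one ceiling: the limit of > 50000 nM in this assay, at which 3 of the 3 values shown sit.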